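A few compounds are considered here, and "the series" means these few. Any claim that something is new, unique, unknown or untested is made for them only; others in the source may bear on it.

Compound 1 `COc1ccccc1OS(=O)(=O)c1ccc(N2CCN(C)C2=O)cc1`: 26000 nM
Compound 2 `CN1CCN(c2ccc(S(=O)(=O)Oc3cccc(F)c3)cc2)C1=O`: > 100000 nM

In a functional assay on HT-29 cells (Homo sapiens) for antiproliferative activity, read by sulforhodamine B assay, with a stated time of 48 h (on this read-out higher numbers stand for weaker inhibition and lower numbers for stronger inhibition), compound 1 gives 26000 nM. For compound 2 the entry > 100000 nM is a limit of the assay and not a number.

Compound 3 `CN1CCN(c2ccc(S(=O)(=O)Oc3cccc(Br)c3)cc2)C1=O` has bromo in place of fluoro on an aromatic carbon.

Among the compounds with values here, only one measured step is available, an at least 3.8-fold higher number from compound 1 to compound 2 (0.58 log units; beyond the scatter), which put 3-fluorophenyl in place of 2-methoxyphenyl on an oxygen. That step, which lies beyond the scatter, ends for compound 2 at the limit of > 100000 nM in this assay, at which 1 of the 2 values shown sits. It gives no direct size for exchanging fluoro with bromo, so only a small change towards a lower number, or none visible, is expected in this assay.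

The expected change is an at least 1.4-fold lower number from compound 2 to compound 3 (0.15 log units; that floor lies within the scatter). Compound 3 is estimated at 70000 nM, with an expected range of 20000 nM to 150000 nM.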

Compound 3, half-maximal inhibitory concentration: 1300 nM
Estimate against measurement, compound 3: 54-fold (1.73 log units) above, outside the stated range (below it).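

In this assay, the group on this aromatic carbon, meta to a large group, turns out to matter greatly: exchanging the single fluoro for bromo gives an at least 76-fold lower number from compound 2 to compound 3 (1.88 log units; beyond the scatter). The entry for compound 2, > 100000 nM, is a limit of the assay and not a number, so this step gives only a floor for the change: the limit of > 100000 nM in this assay, at which 1 of the 3 values shown sits.
The 3-bromophenyl group also outperforms the 2-methoxyphenyl group on the same oxygen, with a 20-fold lower number from compound 1 to compound 3 (1.30 log units; beyond the scatter), which makes compound 3 the most potent of the three compounds shown.

On these data alone, whether chloro, iodo or a methyl group on this carbon would behave more like bromo or more like fluoro stays open. As far as these compounds go, it is also open whether bromo would keep this effect on another carbon of the same ring.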